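Methyl to Fluoro: From 4-Methylphenyl to 4-Fluorophenyl

The source may hold more compounds than are shown below. What is called first, only, known or untested is meant among the compounds shown, and "the series" means these compounds.

Compound 1 `O=C(NO)c1cnc(N2CCN(S(=O)(=O)c3ccc(OC(F)(F)F)cc3)CC2)s1`: 4000 nM
Compound 2 `Cc1ccc(S(=O)(=O)N2CCN(c3ncc(C(=O)NO)s3)CC2)cc1`: 350 nM
Compound 3 `Cc1ccc(S(=O)(=O)N2CCN(c3ncc(/C=C/C(=O)NO)s3)CC2)cc1`: 2000 nM

All three numbers come from a functional assay on MCF7 cells (Homo sapiens) for antiproliferative activity; a lower number here means a stronger inhibitor of growth, a higher number a weaker inhibitor of growth. Compound 3 stands second highest of the three; its nearest neighbour is compound 1, and the gap between them lies within the scatter. For the measured compounds named here, the one step that separates compound 3 clearly is a 5.7-fold higher number from compound 2 to compound 3 (0.76 log units; beyond the scatter).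

Compound 4 `O=C(/C=C/c1cnc(N2CCN(S(=O)(=O)c3ccc(F)cc3)CC2)s1)NO` differs from compound 3 by fluoro in place of methyl on an aromatic carbon. Going by the values given here, one measured step touches this same aromatic carbon: an 11-fold lower number from compound 1 to compound 2 (1.06 log units; beyond the scatter), a large shift. That step shows the position matters, but fluoro is a new group here, so its direction is open. A modest weakening in this assay is expected, a 1.5-fold higher number from compound 3 to compound 4 (0.18 log units; within the scatter). For compound 4 the estimate is 3000 nM, expected to fall between 1000 nM and 10000 nM.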

Compound 4, concentration for 50% growth inhibition: 2500 nM
Compound 4: the middle estimate sits 1.2-fold (0.08 log units) above what was measured; the measured number falls inside the stated range.
By their numbers in this assay, from the lowest: compound 2; then compounds 3, 4 and 1 (each within the scatter of the next).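

Fluoro in place of methyl on this aromatic carbon gives a 1.3-fold higher number from compound 3 to compound 4 (0.10 log units; within the scatter) in this assay, so the two groups cannot be told apart in compounds carrying the 2-(hydroxycarbamoyl)ethenyl group. This position therefore does not respond to every change, although an 11-fold lower number from compound 1 to compound 2 (1.06 log units; beyond the scatter) was seen with trifluoromethoxy and methyl in compounds carrying hydroxycarbamoyl instead. No measurement at hand explains this result. Among the compounds shown, fluoro appears only with the 2-(hydroxycarbamoyl)ethenyl group, so its effect alongside hydroxycarbamoyl stays open. Going by these compounds, how chloro or an amine on this carbon would read also stays open.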